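Branched alkyl amine in place of the hydroxypropyl chain

The compounds below may be only part of what the source reports. "The series", "measured", "known", "first", "only" and "open" are said of these compounds alone.

Compound 3 `OCCCN[C@@H]1C=C[C@H](O)[C@H](O)[C@H]1O` stands at the bottom of the measured set. In an assay for inhibition of beta-galactosidase (Homo sapiens), read by fluorescence, with a stated time of 30 min, at pH 4.5 (on this read-out higher numbers stand for weaker inhibition and lower numbers for stronger inhibition), compound 3 gives only a limit, > 1000000 nM, the limit described by the limit of > 1000000 nM in this assay, at which 1 of the 3 values shown sits. Compound 1 `CCCCCCCCN[C@@H]1C=C[C@H](O)[C@H](O)[C@H]1O` gives 120000 nM in this assay, and compound 2 `CCCCN[C@@H]1C=C[C@H](O)[C@H](O)[C@H]1O` gives 50000 nM in this assay. The steps toward compound 3 are the ones that matter here: an at least 20-fold higher number from compound 2 to compound 3 (1.30 log units; beyond the scatter) and an at least 8.3-fold higher number from compound 1 to compound 3 (0.92 log units; beyond the scatter), both in the direction of weaker inhibition when a hydroxy enters the chain. Among the all-carbon chains the step is smaller, a 2.4-fold lower number from compound 1 to compound 2 (0.38 log units; beyond the scatter).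

Compound 4 `CCC(CC)N[C@@H]1C=C[C@H](O)[C@H](O)[C@H]1O` reverses that direction: pentan-3-yl in place of 3-hydroxypropyl on an amine nitrogen. The hydroxy leaves and a branched alkyl of similar length to the butyl of compound 2 enters. Among the compounds with values here, the expected move in this assay is therefore a large step toward lower numbers, an at least 12-fold lower number from compound 3 to compound 4 (1.09 log units; beyond the scatter), though the branching has no measured precedent in this set. Compound 4 is estimated at 80000 nM in this assay, with a plausible range from 20000 nM to 400000 nM.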

Compound 4, half-maximal inhibitory concentration: > 1000000 nM
Compound 4 gave a limit, no number (the forecaster's own chance of this, stated with the estimate: 10%); at least 12-fold (1.09 log units) between middle value and limit.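

At the amine nitrogen, removing the hydroxy is not enough to give a readable value in this assay: compound 4, whose pentan-3-yl has 0 hydrogen-bond donors and 0 hydrogen-bond acceptors, still ends at a limit and not at a number. An all-carbon substituent therefore does not guarantee a measurable value, as compound 1 and compound 2 alone might have suggested, and the branched pentan-3-yl in place of the straight butyl gives an at least 20-fold higher number from compound 2 to compound 4 (1.30 log units; beyond the scatter). Compound 3 and compound 4 rest at the same limit, so the step between them cannot be read: the limit of > 1000000 nM in this assay, at which 2 of the 4 values shown sit.

Going by these compounds, whether branching or chain length drives the loss stays open, and a straight pentyl chain or an isopropyl group on the same amine nitrogen would help separate the two. On these data alone, whether compound 3 and compound 4 differ at all beyond the limit also remains open.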